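This account rests on a few compounds, and the source may have more. Where it says the series, first, only, none or still open, it means among the compounds named here.

Three ureas on the shared core have been measured in an assay on isolated protein for inhibition of histamine H2 receptor (Cavia porcellus); a higher number here means weaker binding, a lower number tighter binding. Compound 1 `O=C(NCCCOc1cccc(CN2CCCCC2)c1)NCc1ccccc1` gives 347 nM, compound 2 `CC(C)CNC(=O)NCCCOc1cccc(CN2CCCCC2)c1` gives 170 nM and compound 3 `Cc1ccc(NC(=O)NCCCOc2cccc(CN3CCCCC3)c2)cc1` gives 631 nM. Compound 3 thus carries the highest number of the three; the step of a 1.8-fold higher number from compound 1 to compound 3 (0.26 log units; within the scatter) lies within the scatter, whereas a 3.7-fold higher number from compound 2 to compound 3 (0.57 log units; beyond the scatter) lies beyond it. Compound 4 `O=C(NCCCOc1cccc(CN2CCCCC2)c1)Nc1ccc(C(F)(F)F)cc1` differs from compound 3 by trifluoromethyl in place of methyl on an aromatic carbon. Within the data shown here, none of the measured steps bears directly on this change: a 2.0-fold lower number from compound 1 to compound 2 (0.31 log units; beyond the scatter) and the two steps into compound 3 all exchange the group on the urea nitrogen itself, not a substituent on the aryl ring. Among the measured compounds shown here, no measured step therefore supports a move in this assay beyond the scatter in either direction. Compound 4 is expected to give about 550 nM, with a range from 200 nM to 1500 nM. The expected step is a 1.1-fold lower number from compound 3 to compound 4 (0.06 log units; within the scatter).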

Compound 4, dissociation constant: 1700 nM
Compound 4: the middle estimate sits 3.1-fold (0.49 log units) below what was measured; the whole stated range lies below it.
By their numbers in this assay, from the lowest: compound 2; then compounds 1 and 3 (each within the scatter of the next); then compound 4.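

In this assay the substituent on the aryl ring proves to matter: trifluoromethyl in place of methyl on an aromatic carbon gives a 2.7-fold higher number from compound 3 to compound 4 (0.43 log units; beyond the scatter) and so moves the number beyond the scatter. The 4-(trifluoromethyl)phenyl group also separates clearly from the other urea substituents, with a 4.9-fold higher number from compound 1 to compound 4 (0.69 log units; beyond the scatter) and a 10-fold higher number from compound 2 to compound 4 (1.00 log units; beyond the scatter) as the two steps, which leaves compound 4 with the highest number of the four. No evidence in hand accounts for this change.

Open, on these data alone, is how other groups would read at this place, such as a chlorine, a methoxy group or an amine. As far as these compounds go, it is also open whether the same exchange on a benzyl ring would give a step of similar size.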